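This account rests on a few compounds, and the source may have more. Where it says the series, first, only, none or still open, it means among the compounds named here.

Compound 1 `O=C1C=CC(O)(c2ccccc2)C=C1` gives 1700 nM
Compound 2 `COc1ccc(-n2cc(C3(O)C=CC(=O)C=C3)nn2)cc1` gives 310 nM
Compound 3 `CN1CCN(C(=O)CCc2ccc(S(=O)(=O)n3c(C4(O)C=CC(=O)C=C4)cc4ccccc43)cc2)CC1` gives 52 nM

In an ADME assay on MRC5 cells (Homo sapiens) for cytotoxicity, read by fluorescence and resazurin assay, with a stated time of 3 days (on this read-out higher numbers stand for an effect only at larger amounts of compound and lower numbers for an effect already at smaller amounts), compound 2 at 310 nM stands second highest of the three, with compound 1 higher and compound 3 lower, both gaps lying beyond the usual scatter. Compound 4 `N=C(N)c1ccc(-n2cc(C3(O)C=CC(=O)C=C3)nn2)cc1` differs from compound 2 in one place: on an aromatic carbon, para to a large group, methoxy gives way to a group of 3 heavy atoms (1 carbon, 2 nitrogen; no ring) a group of 3 heavy atoms (1 carbon, 2 nitrogen; no ring) in place of a group of 2 heavy atoms (1 carbon, 1 oxygen; no ring), on an aromatic carbon and the rest stays the same. Among the compounds with values here, no measured pair shows this kind of change, so any expectation is cautious. In this assay the expected move is small and upward, a 1.6-fold higher number from compound 2 to compound 4 (0.21 log units; within the scatter), probably within the scatter. For compound 4 the estimated value is 500 nM, expected to fall between 120 nM and 2000 nM in most repeats.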

Compound 4, half-maximal effective concentration: > 50000 nM
Compound 4: a limit, no number; the forecaster's own chance of this, stated with the estimate: 5%; at least 100-fold (2.00 log units) between middle value and limit.
By their numbers in this assay, from the lowest: compound 3; then compound 2; then compound 1. At a limit, above all of these: compound 4.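

Within the data shown here, the earlier compounds offered no one-place comparison, so this is the first sign that the aromatic carbon para to a large group matters in this assay. Putting the group of 3 heavy atoms (1 carbon, 2 nitrogen) in place of methoxy there gives an at least 160-fold higher number from compound 2 to compound 4 (2.20 log units; beyond the scatter). For compound 4 this reading is a limit, not a number: the limit of > 50000 nM in this assay, at which 1 of the 4 values shown sits.

On these data alone, how far compound 4 really lies past that limit stays open. So does whether an amine, a carboxylic acid or a longer chain at this position would shift the number as strongly.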